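Adding a Methoxy Group to the Sulfonyl Aryl Ring

The source may hold more compounds than are shown below. What is called first, only, known or untested is meant among the compounds shown, and "the series" means these compounds.

Compound 1 `Cc1ccc(N2CCN(c3ccc(C(=O)/C=C/c4ccccc4)cc3)CC2)c(C)c1` gives 15% in a functional assay on the whole organism (strain Kunming) for inhibition, with Mus musculus as the target, with a stated time of 1 h, at a dose of 40 mg/kg by the oral route; a lower number here means less inhibition, a higher number more inhibition at the dose given (going by the name of the read-out). Compound 2 `Cc1ccc(N2CCN(c3ccc(C(=O)/C=C/c4ccccc4)cc3)CC2)cc1` gives 2.85%. Compound 3 `COc1ccc(S(=O)(=O)N2CCN(c3ccc(C(=O)/C=C/c4ccccc4)cc3)CC2)cc1` gives 45.2%.

Compound 3 stands highest of the three measured compounds: the step of a number 30.2 percentage points higher from compound 1 to compound 3 (beyond the scatter) and the step of a number 42.4 percentage points higher from compound 2 to compound 3 (beyond the scatter) are both large. Compound 4 `COc1ccc(S(=O)(=O)N2CCN(c3ccc(C(=O)/C=C/c4ccccc4)cc3)CC2)cc1OC` differs from compound 3 by methoxy in place of hydrogen on an aromatic carbon. Going by the values given here, no measured step changes this ring, so nothing bears directly on it. The nearest guide is a number 12.2 percentage points lower from compound 1 to compound 2 (beyond the scatter), a modest step from removing a small group on an aromatic carbon elsewhere. A modest step in either direction, or none beyond the scatter, is therefore expected. Compound 4 is estimated to give 48%, between 25% and 70%, which is the expected step of a number 2.8 percentage points higher from compound 3 to compound 4 (within the scatter).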

Compound 4, a percentage reported as inhibition, in the whole organism at one dose (the size of the read-out at that dose, not a potency): 55.5%
For compound 4 the middle estimate is 7.5 percentage points below the measured one; the range from low to high includes it.
By their numbers in this assay, from the lowest: compound 2; then compound 1; then compound 3; then compound 4.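

Going by these compounds alone, changing 4-methoxyphenyl to 3,4-dimethoxyphenyl gives in this assay a step of a number 10.3 percentage points higher from compound 3 to compound 4 (beyond the scatter) and is the first measured change on this ring. It shows that the ring responds to substitution and that a methoxy group ortho to the existing methoxy group keeps the inhibition and adds modestly to it. Nothing measured here explains that gain. Still open, from the compounds shown here alone, is whether the new oxygen matters, which an ethyl group or a chlorine atom at this position could test. Going by these compounds, a hydroxyl group or an amine there also remains unexplored.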